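Moving the Methoxy Group of Compound 1

This account rests on a few compounds, and the source may have more. Where it says the series, first, only, none or still open, it means among the compounds named here.

Compound 1 `CCCc1nc(-c2ccccc2)c(CNCCN2CCN(c3ccccc3OC)CC2)o1` was tested in an assay on HEK293 cells for inhibition of Voltage-dependent T-type calcium channel subunit alpha-1G (Homo sapiens), read by fluorescence, tested at 10 uM (on this read-out lower numbers stand for less inhibition and higher numbers for more inhibition at the one concentration tested (going by the name of the read-out)), where compound 1 gives 39.7%. Two related compounds were measured in the same way: compound 2 `CCCc1nc(-c2ccccc2)c(CNCCCN2CCN(c3cccc(F)c3)CC2)o1` gives 68.9%, and compound 3 `CCCc1nc(-c2ccccc2)c(CNCCCN2CCN(c3cccc(Cl)c3)CC2)o1` gives 65.9%. Compound 1 therefore shows the lowest of the three numbers, with compound 3 the nearest and compound 2 the furthest, both gaps beyond the scatter. Within the data shown here, the only measured step, a number 3 percentage points lower from compound 2 to compound 3 (within the scatter), concerns chloro in place of fluoro on an aromatic carbon and lies within the scatter.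

Compound 4 `CCCc1nc(-c2ccccc2)c(CNCCN2CCN(c3ccc(OC)cc3)CC2)o1` differs from compound 1 only in how the same atoms are joined: 4-methoxyphenyl in place of 2-methoxyphenyl on an amine nitrogen in a ring. Among the measured compounds shown here, no measured step involves a methoxyphenyl group, and compounds 2 and 3 differ from compound 1 in more than one place, so none of them gives a direct guide to this change. The expectation is thus a step of uncertain direction, a number 5.3 percentage points higher from compound 1 to compound 4 (within the scatter), with a wide range around it. Compound 4 is estimated at 45%, expected to lie between 20% and 72%.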

Compound 4, a percentage reported as inhibition, at one concentration (the size of the read-out at that concentration, not a potency): 51.5%
Beside the measured number, compound 4's estimate is 6.5 percentage points below it; low and high end bracket the measured number.
By their numbers in this assay, from the lowest: compound 1; then compound 4; then compounds 3 and 2 (each within the scatter of the next).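

Moving the methoxy group is enough to shift the reading in this assay and 4-methoxyphenyl in place of 2-methoxyphenyl on an amine nitrogen in a ring gives a number 11.8 percentage points higher from compound 1 to compound 4 (beyond the scatter) as the first step measured at this position. The two groups have the same heavy atoms, the same count of hydrogen-bond acceptors and no net charge, so at this position a difference in how the atoms are joined can alone change the number. No evidence on why the number rises is available here.

Among these compounds, only two placements of one group can be compared at this position, so a single step cannot show whether other groups would follow the same direction. Going by these compounds, it remains open how 4-ethoxyphenyl or 4-hydroxyphenyl on the same ring nitrogen would read, with the rest of compound 4 kept unchanged.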